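Turning a hydroxyphenyl arm back toward the ring junction

This account rests on a few compounds, and the source may have more. Where it says the series, first, only, none or still open, it means among the compounds named here.

Compound 1, `Oc1cccc(-c2cc(-c3cccc(O)c3)nc(-c3ccccc3O)c2)c1`: 50000 nM
Compound 2, `Oc1ccc(-c2cc(-c3cccc(O)c3)cc(-c3cccc(O)c3)n2)cc1`: 3920 nM
Compound 3, `Oc1cccc(-c2cc(-c3cccc(O)c3)nc(-c3cccc(O)c3)c2)c1`: 2050 nM

In a functional assay on T47D cells (Homo sapiens) for cytotoxicity, read by CCK-8 assay, with a stated time of 4 days (a lower number here means a stronger inhibitor, a higher number a weaker inhibitor), compound 1 gives 50000 nM, the highest number among the three measured compounds. Replacing its 2-hydroxyphenyl arm with 4-hydroxyphenyl gave a 13-fold lower number from compound 1 to compound 2 (1.11 log units; beyond the scatter), and replacing it with 3-hydroxyphenyl gave a 24-fold lower number from compound 1 to compound 3 (1.39 log units; beyond the scatter). Compounds 2 and 3 differ from each other by a 1.9-fold lower number from compound 2 to compound 3 (0.28 log units; within the scatter), so those two are not separated by the data.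

Compound 4, `Oc1cccc(-c2cc(-c3ccccc3O)cc(-c3ccccc3O)n2)c1`, goes the other way on the shared core: 2-hydroxyphenyl in place of 3-hydroxyphenyl on an aromatic carbon. Compound 4 therefore carries two 2-hydroxyphenyl groups where compound 1 carries one. The two measured steps that bear on this both show that removing a 2-hydroxyphenyl group lowers the number by a large amount, so adding one is expected to move the number in the opposite direction, upward, or at best to leave it at the high value of compound 1. Since compound 1 already sits at the top of the range, a further rise may not be resolved as a number.

For compound 4 in this assay the estimate is 60000 nM, within a range from 20000 nM to 150000 nM, which is expected to correspond to a 1.2-fold higher number from compound 1 to compound 4 (0.08 log units; within the scatter).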

Compound 4, half-maximal inhibitory concentration: 5760 nM
Compound 4: the middle estimate sits 10-fold (1.02 log units) above what was measured; measured number below the stated range.
By their numbers in this assay, from the lowest: compounds 3, 2 and 4 (each within the scatter of the next, the first and the last beyond it); then compound 1.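

In this assay, placing 2-hydroxyphenyl in place of 3-hydroxyphenyl opposite the ring nitrogen gives an 8.7-fold lower number from compound 1 to compound 4 (0.94 log units; beyond the scatter), even though compound 4 carries one more 2-hydroxyphenyl group than compound 1. The earlier steps had only shown the number falling when a 2-hydroxyphenyl group left, so this step shows that on the shared core, this group does not raise the number wherever it stands, and that its place matters as well as its presence. The high number of compound 1 therefore cannot be read as a simple penalty for carrying a 2-hydroxyphenyl group, and nothing in the available data accounts for the difference between the two arrangements.

The compounds shown leave open how 4-hydroxyphenyl would behave opposite the ring nitrogen, and whether a third 2-hydroxyphenyl group on the core would continue this trend or reverse it. They also leave open whether the hydroxyl itself matters on these arms, which a methoxy group, an amine or a carboxylic acid in its place would begin to test.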